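Swapping a Methoxyphenyl Arm for a Methoxyphenylethyl Arm

The source may hold more compounds than are shown below. What is called first, only, known or untested is meant among the compounds shown, and "the series" means these compounds.

Measured compounds:
- Compound 1, `CCCCCCCCS(=O)(=O)Nc1cc(-c2ccccc2OC)ccc1C(=O)O`: 16100 nM
- Compound 2, `CCCCCCCCS(=O)(=O)Nc1ccc(C(=O)c2ccc(CCCC)cc2)cc1C(=O)O`: 31700 nM
- Compound 3, `CCCCCCCCS(=O)(=O)Nc1ccc(C(=O)c2ccc(-c3ccccc3)cc2)cc1C(=O)O`: 13000 nM

All three compounds were tested in an assay on mitochondria (strain BALB/c) for inhibition of glycerol-3-phosphate acyltransferase 1, mitochondrial (Mus musculus), read by scintillation counting, with a stated time of 10 min; on this read-out higher numbers stand for weaker inhibition and lower numbers for stronger inhibition. Compound 1 gives 16100 nM, a number that lies between those of compound 2 and compound 3, and both gaps fall within the usual scatter, so these three cannot be told apart on potency.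

Compound 4, `CCCCCCCCS(=O)(=O)Nc1cc(CCc2ccc(OC)cc2)ccc1C(=O)O`, is not yet measured. It differs from compound 1 in one place: 2-(4-methoxyphenyl)ethyl in place of 2-methoxyphenyl on an aromatic carbon.

Going by the values given here, the only measured step, a 2.4-fold lower number from compound 2 to compound 3 (0.39 log units; beyond the scatter), concerns a change on the other arm of a different pair of compounds and does not bear on this exchange. Nothing measured speaks to replacing a directly attached methoxyphenyl with a methoxyphenylethyl group, so no step beyond the scatter is expected in this assay .

Compound 4 is therefore expected to give about 16000 nM, with a range from 6000 nM to 45000 nM. The expected step is a 1.0-fold lower number from compound 1 to compound 4 (0.00 log units; within the scatter).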

Compound 4, half-maximal inhibitory concentration: 43000 nM
Compound 4: the middle estimate sits 2.7-fold (0.43 log units) below what was measured; the measured number falls inside the stated range.
By their numbers in this assay, from the lowest: compounds 3, 1, 2 and 4 (each within the scatter of the next, the first and the last beyond it).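

At this position, para to a carboxy group, the arm is not freely interchangeable: in this assay, 2-(4-methoxyphenyl)ethyl in place of 2-methoxyphenyl gives a 2.7-fold higher number from compound 1 to compound 4 (0.43 log units; beyond the scatter), a modest loss of inhibition and the first step measured at this place on the shared core. The exchange changes two features together, adding an ethyl link and moving the methoxy group around the ring, so this single step cannot show which of them accounts for the change. Nothing available explains the weaker inhibition.

Still open, on these data alone, is whether a directly attached 4-methoxyphenyl or a 2-(2-methoxyphenyl)ethyl group would separate these two features. Also open, as far as these compounds go, is whether an amine or a carboxylic acid in place of the methoxy group would give a lower number in this assay.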